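Amide-nitrogen aryl swap toward a dimethoxyphenyl analogue

The source may hold more compounds than are shown below. What is called first, only, known or untested is meant among the compounds shown, and "the series" means these compounds.

Compound 3 `O=C(NCCCCc1ccccc1)c1cccc(C2SCC(=O)N2c2ccccc2F)c1` gives 95% in a functional assay on HOS-TE85 cells (Homo sapiens) for inhibition, read by CCK-8 assay, with a stated time of 72 h, tested at 1 uM; on this read-out higher numbers stand for more inhibition at the one concentration tested (going by the name of the read-out) and lower numbers for less inhibition. Compound 1 `COc1ccc(C)cc1N1C(=O)CSC1c1cccc(C(=O)NCCCCc2ccccc2)c1` gives 95%, and no change at the digits printed from compound 1 to compound 3 (within the scatter), so compound 3 stands level with compound 1, the two together the highest of the three numbers. Compound 2 `COc1ccc(OC)c(N2C(=O)CSC2c2cccc(C(=O)NCCCCc3ccccc3)c2)c1` gives 20%, the lowest, with a number 75 percentage points higher from compound 2 to compound 3 (beyond the scatter).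

Compound 4 `COc1ccc(N2C(=O)CSC2c2cccc(C(=O)NCCCCc3ccccc3)c2)c(OC)c1` is not yet measured. It differs from compound 3 by 2,4-dimethoxyphenyl in place of 2-fluorophenyl on an amide-type nitrogen in a ring. Going by the values given here, two measured steps bear on this. First, a number 75 percentage points higher from compound 2 to compound 3 (beyond the scatter), the reverse of which is the exchange of 2-fluorophenyl for a dimethoxyphenyl on the same amide-type nitrogen in a ring. Second, a number 75 percentage points lower from compound 1 to compound 2 (beyond the scatter), where a second methoxy enters an aryl on that nitrogen. The group entering compound 4 is 2,4-dimethoxyphenyl, not the 2,5-dimethoxyphenyl of compound 2, so the match is partial, and no direct measurement of it exists.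

A large downward step is therefore expected, though with wide uncertainty: the estimate for compound 4 is 45%, range 10% to 90%, implying an expected a number 50 percentage points lower from compound 3 to compound 4 (beyond the scatter).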

Compound 4, a percentage reported as inhibition, at one concentration (the size of the read-out at that concentration, not a potency): 58%
Compound 4: middle estimate off by 13 percentage points, on the low side; the range from low to high includes it.
By their numbers in this assay, from the lowest: compound 2; then compound 4; then compounds 1 and 3 (each within the scatter of the next).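

In this assay, 2,4-dimethoxyphenyl and 2,5-dimethoxyphenyl on the amide-type nitrogen are not interchangeable, with a number 38 percentage points higher from compound 2 to compound 4 (beyond the scatter), so the presence of two methoxy groups does not alone fix the read-out at this position. Against the two highest compounds, the change to 2,4-dimethoxyphenyl still gives a number 37 percentage points lower from compound 3 to compound 4 (beyond the scatter) and a number 37 percentage points lower from compound 1 to compound 4 (beyond the scatter), which adds an intermediate level to the high and low numbers seen earlier; both dimethoxyphenyl compounds sit lower than compounds 1 and 3, and no compound shown goes against this. No supporting data are available to account for these differences.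

As far as these compounds go, it remains open how an aminophenyl or a carboxyphenyl on the same nitrogen would compare with these aryl groups. The single-concentration read-out also leaves open whether these gaps hold at other concentrations.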